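Swapping Thiophene for Benzofuran at the Assay Limit

The source may hold more compounds than are shown below. What is called first, only, known or untested is meant among the compounds shown, and "the series" means these compounds.

In a functional assay on HeLa S3 cells (Homo sapiens) for antiproliferative activity, read by XTT assay, with a stated time of 72 h (a lower number here means a stronger inhibitor, a higher number a weaker inhibitor), compound 3 `COc1nc(N)nc2c1c(-c1ccsc1)cn2[C@@H]1O[C@H](CO)[C@@H](O)[C@H]1O` gives > 20000 nM, which is a limit of the assay and not a number. Compound 2 `COc1nc(N)nc2c1c(-c1ccoc1)cn2[C@@H]1O[C@H](CO)[C@@H](O)[C@H]1O` gives > 20000 nM, which is also a limit. Compound 3 therefore stands at the limit of > 20000 nM in this assay, at which 2 of the 3 values shown sit.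

Compound 4 `COc1nc(N)nc2c1c(-c1cc3ccccc3o1)cn2[C@@H]1O[C@H](CO)[C@@H](O)[C@H]1O` replaces the thiophen-3-yl group of compound 3 with 1-benzofuran-2-yl, on an aromatic carbon of the shared core: 1-benzofuran-2-yl in place of thiophen-3-yl on an aromatic carbon.

For the measured compounds named here, the only measured step between close neighbours is a step that the two limits leave unreadable from compound 2 to compound 3, so it offers no size to carry over. The better clue is compound 1 `COc1ncnc2c1c(-c1cc3ccccc3o1)cn2[C@@H]1O[C@H](CO)[C@@H](O)[C@H]1O`, which carries the same 1-benzofuran-2-yl group, although its core is not the same as that of compound 4. In this assay, going by the values given here, compound 1 gives 9240 nM, the only true number among the measured compounds.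

On the strength of that value of 9240 nM for compound 1, a modest gain in potency is expected. The core difference leaves real doubt, though, and compound 4 could stay at the limit. The expected change is an at least 1.6-fold lower number from compound 3 to compound 4 (0.22 log units; that floor lies within the scatter), and its size is only loosely estimated. For compound 4, the estimate is 12000 nM, with an expected range from 4000 nM to 20000 nM.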

Compound 4, half-maximal inhibitory concentration: > 20000 nM
Compound 4: a limit, no number; the forecaster's own chance of this, stated with the estimate: 35%; middle value at least 1.6-fold (0.22 log units) from the limit.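

In this assay, compound 4 also sits at a limit, so on this amino-bearing shared core, 1-benzofuran-2-yl, with its extra six-membered aromatic ring, does not give a true number in place of thiophen-3-yl or furan-3-yl. The steps to compound 4 from compound 2 and from compound 3 cannot be read, each having a limit at both ends: the limit of > 20000 nM in this assay, at which 3 of the 4 values shown sit. For the compounds shown here, the one readable step keeps 1-benzofuran-2-yl fixed and places amino where compound 1 has hydrogen on an aromatic carbon of the core, and it is an at least 2.1-fold higher number from compound 1 to compound 4 (0.33 log units; beyond the scatter), so the benzofuran group gives a true number only on the core of compound 1.

Going by these compounds, how far compound 2, compound 3 and compound 4 lie past the limit stays unknown, so these three groups cannot be ranked against one another. On these data alone, it also remains open whether thiophen-3-yl, furan-3-yl or a plain phenyl group would give a true number on the core of compound 1, which has no amino group.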